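The source may report more compounds than this note shows. Statements on the series, on what has been measured and on what is new or still open speak of the compounds shown alone.

Measured so far in a functional assay on NCI-H460 cells (Homo sapiens) for cytotoxicity, read by MTT assay, with a stated time of 72 h; on this read-out higher numbers stand for weaker inhibition and lower numbers for stronger inhibition:
- compound 1 `CN(C)CCn1cnnc1-c1cc(Oc2ccc(NC(=O)N/N=C/c3cccc(Cl)c3Cl)cc2F)ccn1` gives 72 nM
- compound 2 `CN(C)CCn1cnnc1-c1cc(Oc2ccc(NC(=O)N/N=C/c3ccc(O)c(F)c3)cc2F)ccn1` gives 2620 nM
- compound 3 `CN(C)CCn1cnnc1-c1cc(Oc2ccc(NC(=O)N/N=C/c3ccc(O)cc3)cc2F)ccn1` gives 1780 nM

Compound 3 stands second highest of the three numbers. Its nearest neighbour is compound 2: a 1.5-fold lower number from compound 2 to compound 3 (0.17 log units; within the scatter). Its furthest is compound 1: a 25-fold higher number from compound 1 to compound 3 (1.39 log units; beyond the scatter).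

Compound 4 `CN(C)CCn1cnnc1-c1cc(Oc2ccc(NC(=O)N/N=C/c3ccccc3O[N+](=O)[O-])cc2F)ccn1` is not yet measured. Change from compound 3: 2-(nitrooxy)phenyl in place of 4-hydroxyphenyl on a carbon with a double bond to nitrogen.

For the measured compounds named here, the steps that bear on it are those that swap the whole aryl group on the carbon with a double bond to nitrogen. Both were large: a 36-fold higher number from compound 1 to compound 2 (1.56 log units; beyond the scatter) and a 25-fold higher number from compound 1 to compound 3 (1.39 log units; beyond the scatter). Going by the values given here, neither involves a 2-(nitrooxy)phenyl group, so the direction is uncertain; what the data show is that the only measured compound without a hydroxyl on that ring, compound 1, carries the lowest number, while the step of a 1.5-fold lower number from compound 2 to compound 3 (0.17 log units; within the scatter) shows that small changes on a hydroxyphenyl ring leave the number within scatter.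

A moderate step down is therefore expected, a 3.6-fold lower number from compound 3 to compound 4 (0.55 log units; beyond the scatter), and compound 4 is estimated at 500 nM, range 100 nM to 2500 nM.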

Compound 4, half-maximal inhibitory concentration: 1270 nM
Beside the measured number, compound 4's estimate is 2.5-fold (0.40 log units) below it; the measured number falls inside the stated range.
By their numbers in this assay, from the lowest: compound 1; then compounds 4, 3 and 2 (each within the scatter of the next, the first and the last beyond it).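

In this assay the 2-(nitrooxy)phenyl group on the carbon with a double bond to nitrogen sits with the 4-hydroxyphenyl group (a 1.4-fold lower number from compound 3 to compound 4 (0.15 log units; within the scatter)), so lacking a hydroxyl on this ring is not enough to reach the low number of compound 1. The other two steps differ in size, modest against the 3-fluoro-4-hydroxyphenyl group (a 2.1-fold lower number from compound 2 to compound 4 (0.31 log units; beyond the scatter)) and large against the 2,3-dichlorophenyl group (an 18-fold higher number from compound 1 to compound 4 (1.25 log units; beyond the scatter)), which leaves compound 1 alone among the four. Nothing available explains these differences at this position.

On these data alone, whether the low number of compound 1 depends on having both chloro groups, or would hold with a single chloro group, stays open. Also open, as far as these compounds go, is how an amine or a carboxylic acid on this ring would compare.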